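Bis-benzylidene cyclohexanones: a dihydroxyphenyl variant

The compounds below may be only part of what the source reports. "The series", "measured", "known", "first", "only" and "open" are said of these compounds alone.

Three members of this series have been measured in a functional assay on SW-620 cells (Homo sapiens) for cytotoxicity, read by MTT assay, with a stated time of 72 h; a lower number here means a stronger inhibitor, a higher number a weaker inhibitor. Compound 1 `COc1cccc(/C=C2\CCC/C(=C\c3cccc(O)c3)C2=O)c1OC` gives 6400 nM. Compound 2 `COc1cc(/C=C2\CCC/C(=C\c3cccc(OC)c3OC)C2=O)cc(OC)c1` gives 3800 nM. Compound 3 `COc1ccc(/C=C2\CCC/C(=C\c3ccccc3Br)C2=O)cc1OC` gives 5300 nM, the second highest of the three numbers; its nearest neighbour is compound 1 and its furthest is compound 2, and both gaps fall within the usual scatter of this assay, so the three compounds are not separable on these data.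

Compound 4 `COc1ccc(/C=C2\CCC/C(=C\c3ccc(O)c(O)c3)C2=O)cc1OC` has not yet been measured. It differs from compound 3 by 3,4-dihydroxyphenyl in place of 2-bromophenyl on a double-bonded chain carbon bound to a double-bonded ring carbon. Among the compounds with values here, no step between two measured compounds tests this exchange directly. Compound 1, which also carries a hydroxyl-bearing ring on one side, gives a number within the scatter of compound 3, so no movement beyond the scatter is expected in this assay from the change; the step from compound 3 to compound 4 is estimated as a 1.3-fold lower number from compound 3 to compound 4 (0.12 log units; within the scatter), a small move toward a lower number at most. Compound 4 is expected to give 4000 nM in this assay, with a range from 1500 nM to 12000 nM.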

Compound 4, half-maximal inhibitory concentration: 10500 nM
The estimate for compound 4 lay 2.6-fold (0.42 log units) below the measured number; measured number inside the range.
By their numbers in this assay, from the lowest: compounds 2, 3, 1 and 4 (each within the scatter of the next, the first and the last beyond it).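

In this assay, within the data shown here, the exchange of 2-bromophenyl for 3,4-dihydroxyphenyl on a double-bonded chain carbon bound to a double-bonded ring carbon reads as a 2.0-fold higher number from compound 3 to compound 4 (0.30 log units; within the scatter) and is the first single-place step available. It shows that this position takes a ring bearing hydrogen-bond donors in place of one bearing none without a move beyond the scatter, although the step lies at the very edge of it. Nothing measured on these compounds offers an explanation for the step.

Open, as far as these compounds go, is whether an amine or a carboxylic acid on this ring would give a step beyond the scatter. Also open, from the compounds shown here alone, is whether the same exchange gives a similar step when the other side of the core differs from that of compound 3.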